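Anomeric epimer of the monoacyl sulfoquinovosyl glycerol

The source may hold more compounds than are shown below. What is called first, only, known or untested is meant among the compounds shown, and "the series" means these compounds.

Measured compounds:
compound 1 `CCCCCCCCCCCCCCCCCC(=O)OCC(CO[C@@H]1O[C@H](CS(=O)(=O)O)[C@@H](O)[C@H](O)[C@H]1O)OC(=O)CCCCCCCCCCCCCCCCC`, an assay on BL21-DE3 cells for binding affinity to vascular endothelial growth factor A, long form (Homo sapiens), read by surface plasmon resonance; on this read-out lower numbers stand for tighter binding and higher numbers for weaker binding: 0.046 nM
compound 2 `CCCCCCCCCCCCCCCCCC(=O)OCC(CO[C@H]1O[C@H](CS(=O)(=O)O)[C@@H](O)[C@H](O)[C@H]1O)OC(=O)CCCCCCCCCCCCCCCCC`, this assay: 0.025 nM
compound 3 `CCCCCCCCCCCCCCCCCC(=O)OCC(O)CO[C@@H]1O[C@H](CS(=O)(=O)O)[C@@H](O)[C@H](O)[C@H]1O`, this assay: 16000 nM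

Compound 3 gives the highest number of the three; compound 1 and compound 2 both sit far lower, and the gap to each is well beyond the scatter. Compound 4 `CCCCCCCCCCCCCCCCCC(=O)OCC(O)CO[C@H]1O[C@H](CS(=O)(=O)O)[C@@H](O)[C@H](O)[C@H]1O` is not yet measured. It differs from compound 3 only in this: the two compounds have the same atoms and bonds; at least one stereo element is drawn with a configuration in one of them and without one in the other: 1 of 6 stereo elements differ; a stereocentre at a saturated ring carbon is drawn R in compound 3 and S in compound 4.

Within the data shown here, the one measured step that bears on this change is the matching pair within the diacyl series, a 1.8-fold lower number from compound 1 to compound 2 (0.26 log units; within the scatter). Among the measured compounds shown here, that pair is also the only evidence on the stereo element in question, (the fact that one of compounds 1 and 2 is drawn with a defined configuration and the other without, at the place where they differ), and it shows the inversion at this ring carbon leaving the number essentially where it was. The same change is therefore expected to leave compound 4 close to compound 3, with no step beyond the scatter.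

Compound 4 is accordingly estimated at 14000 nM, in a range from 5000 nM to 40000 nM, and the expected step is a 1.1-fold lower number from compound 3 to compound 4 (0.06 log units; within the scatter).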

Compound 4, dissociation constant: 18000 nM
Compound 4: middle estimate off by 1.3-fold (0.11 log units), on the low side; the measured number falls inside the stated range.
By their numbers in this assay, from the lowest: compounds 2 and 1 (each within the scatter of the next); then compounds 3 and 4 (each within the scatter of the next).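

Among these compounds, the configuration at this saturated ring carbon had so far been seen only with both acyl chains present; in the monoacyl pair, in this assay, the same change gives a 1.1-fold higher number from compound 3 to compound 4 (0.05 log units; within the scatter). Together with a 1.8-fold lower number from compound 1 to compound 2 (0.26 log units; within the scatter), this means that in both the diacyl and the monoacyl pair, the step stays within the scatter, even though compound 3, at 16000 nM, sits in a far higher range than compound 1, at 0.046 nM. The reading for the monoacyl pair rests on one structural fact: the fact that one of compounds 3 and 4 is drawn with a defined configuration and the other without, at the place where they differ

The compounds shown leave open whether the ring-carbon configuration would remain without a measurable step with a shorter acyl chain on the glycerol. They also leave open what a carboxylic acid in place of the sulfonic acid would do to the number in either series.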